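Benzyloxy for isopentyloxy: a small change at the ether

A few compounds are considered here, and "the series" means these few. Any claim that something is new, unique, unknown or untested is made for them only; others in the source may bear on it.

Compound 3 `CC(C)CCOc1cc(C(F)(F)F)ccc1CNC(=O)C(C)c1ccc(NS(C)(=O)=O)c(F)c1` gives the lowest of three numbers in an assay on CHO cells for antagonist activity at transient receptor potential cation channel subfamily V member 1 (Homo sapiens), read by FLIPR (a higher number here means a weaker inhibitor, a lower number a stronger inhibitor), at 0.5 nM; compound 1 `CCC1CCN(c2cc(C(F)(F)F)ccc2CNC(=O)C(C)c2ccc(NS(C)(=O)=O)c(F)c2)CC1` lies within the scatter of it at 0.7 nM, while compound 2 `CC(C(=O)NCc1ccc(C(F)(F)F)cc1N1CCN(c2ccccc2)CC1)c1ccc(NS(C)(=O)=O)c(F)c1` stands clearly higher at 2 nM, by a 4.0-fold lower number from compound 2 to compound 3 (0.60 log units; beyond the scatter) in reverse. Compound 4 `CC(C(=O)NCc1ccc(C(F)(F)F)cc1OCc1ccccc1)c1ccc(NS(C)(=O)=O)c(F)c1` differs from compound 3 by phenyl in place of isobutyl on a saturated chain carbon bound to an oxygen on an aromatic ring. Among the compounds with values here, no measured step swaps an alkyl for a phenyl at this place; the nearest comparison is a 2.9-fold higher number from compound 1 to compound 2 (0.46 log units; beyond the scatter), where a phenyl arrived on a different ring group and the number rose modestly. On that footing a small loss is expected, estimated as a 2.0-fold higher number from compound 3 to compound 4 (0.30 log units; within the scatter). Compound 4 is therefore estimated at 1 nM, within 0.3 nM to 3.5 nM.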

Compound 4, inhibition constant: 0.9 nM
Compound 4: the middle estimate sits 1.1-fold (0.05 log units) above what was measured, and the stated range covers the measured number.
By their numbers in this assay, from the lowest: compounds 3, 1 and 4 (each within the scatter of the next); then compound 2.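

In this assay, a phenyl on the saturated chain carbon bound to the ether oxygen stays within the scatter of isobutyl (a 1.8-fold higher number from compound 3 to compound 4 (0.26 log units; within the scatter)), so this place accepts an aromatic ring as well as a branched alkyl. Benzyloxy also stays level with 4-ethylpiperidin-1-yl (a 1.3-fold higher number from compound 1 to compound 4 (0.11 log units; within the scatter)) and gives a lower number than 4-phenylpiperazin-1-yl (a 2.2-fold lower number from compound 2 to compound 4 (0.35 log units; beyond the scatter)), so carrying a phenyl does not by itself bring the number of compound 2. No supporting evidence bears on these results. Still open, on these data alone, is how a fluorine or a methoxy on the benzyl phenyl would read here. A pyridine ring in place of that phenyl, or a longer chain such as phenethyl, also remains untested in the compounds shown.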